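Silyl ether series: methoxycarbonyl in place of methoxy

This account rests on a few compounds, and the source may have more. Where it says the series, first, only, none or still open, it means among the compounds named here.

Measured in an ADME assay on HT-29 cells (Homo sapiens) for cytotoxicity, read by MTT assay, with a stated time of 72 h; a higher number here means a weaker inhibitor, a lower number a stronger inhibitor:
compound 1 `COc1ccc(C2=C(c3cc(OC)c(OC)c(OC)c3)C(=O)CC2O[SiH2]C(C)(C)C)cc1OC`: > 100 ug/mL
compound 2 `COc1ccc(C2=C(c3cc(OC)c(OC)c(OC)c3)C(=O)C(OC(C)=O)C2)cc1Cl`: < 1 ug/mL
compound 3 `COc1ccc(C2=C(c3cc(OC)c(OC)c(OC)c3)C(=O)C(O[SiH2]C(C)(C)C)C2)cc1OC(C)C`: 9 ug/mL

In this assay compound 1 gives only a limit, > 100 ug/mL, which is the limit of > 100 ug/mL in this assay, at which 1 of the 3 values shown sits; no number of its own is known for it. Compound 2 likewise gives a limit, < 1 ug/mL, which is the limit of < 1 ug/mL in this assay, at which 1 of the 3 values shown sits. Compound 3 gives a number, 9 ug/mL. Compound 1 therefore stands at one edge of what has been measured, and nothing in the three values tells how far beyond that edge it lies. For the measured compounds named here, no step between two measured compounds differing in one place is available, so no measured step can guide the next one.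

Compound 4 `COC(=O)c1cc(C2=C(c3cc(OC)c(OC)c(OC)c3)C(=O)CC2O[SiH2]C(C)(C)C)ccc1OC` is the compound not yet measured. It differs from compound 1 in a single place: methoxycarbonyl in place of methoxy on an aromatic carbon. Because compound 1 sits at the limit of > 100 ug/mL in this assay, at which 1 of the 3 values shown sits, any change in this assay that leaves compound 4 at the same limit would not be seen at all. The expectation is that the step of an at least 1.1-fold lower number from compound 1 to compound 4 (0.04 log units; that floor lies within the scatter) stays within the scatter, with a fair chance that only a limit is reported again. Compound 4 is expected to give 90 ug/mL, in the range 25 ug/mL to 300 ug/mL.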

Compound 4, half-maximal inhibitory concentration: > 100 ug/mL
Compound 4 was reported as a limit; the forecaster's own chance of this, stated with the estimate: 55%; middle value at least 1.1-fold (0.04 log units) away from the limit.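

In this assay compound 4 gives > 100 ug/mL, a limit and not a number. Compound 1 also gives only a limit, so no step can be read between compound 1 and compound 4: the limit of > 100 ug/mL in this assay, at which 2 of the 4 values shown sit.

On these data alone, whether methoxycarbonyl in place of methoxy on an aromatic carbon changes the value at all remains open, as does how far beyond the limit either compound lies.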